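Bromo step on the core of compound 1

A few compounds are considered here, and "the series" means these few. Any claim that something is new, unique, unknown or untested is made for them only; others in the source may bear on it.

Of the compounds shown here, three have numbers so far in a functional assay on MCF7 cells (Homo sapiens) for cytotoxicity, read by MTT assay, with a stated time of 24 h; a lower number here means a stronger inhibitor, a higher number a weaker inhibitor. Compound 1 `Nc1cccn2cc(Cc3ccccc3)c(=O)nc12` gives 105000 nM, the second highest of the three numbers. Compound 2 `Nc1cccn2cc(Cc3ccc(F)cc3)c(=O)nc12` gives 135000 nM, and compound 3 `O=c1nc2ccccn2cc1Cc1ccccc1` gives 75400 nM. Both steps from compound 1 stay within the scatter. Fluoro in place of hydrogen on an aromatic carbon gives a 1.3-fold higher number from compound 1 to compound 2 (0.11 log units; within the scatter), and hydrogen in place of amino on an aromatic carbon gives a 1.4-fold lower number from compound 1 to compound 3 (0.14 log units; within the scatter).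

Compound 4 `Nc1cc(Br)cn2cc(Cc3ccccc3)c(=O)nc12` is still unmeasured and carries bromo in place of hydrogen on an aromatic carbon of the shared core: bromo in place of hydrogen on an aromatic carbon. Going by the values given here, no bromo compound has a number yet, so no measured step is a direct precedent. The nearest guide is the halogen step a 1.3-fold higher number from compound 1 to compound 2 (0.11 log units; within the scatter), although compound 2 carries its fluoro at another place in the structure. Among the compounds with values here, the amino step a 1.4-fold lower number from compound 1 to compound 3 (0.14 log units; within the scatter) is the only change on the core so far, and compound 3 also stays within the scatter of compound 1. On this evidence, no step beyond the scatter is expected in this assay, and neither direction is favoured. The estimated step is a 1.1-fold lower number from compound 1 to compound 4 (0.04 log units; within the scatter). The expected value for compound 4 is 95000 nM, with an estimated range from 50000 nM to 170000 nM.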

Compound 4, half-maximal inhibitory concentration: > 1000000 nM
Compound 4 ended at the assay's limit; the forecaster's own chance of this, stated with the estimate: 8%; middle value at least 10-fold (1.02 log units) from the limit.
By their numbers in this assay, from the lowest: compounds 3, 1 and 2 (each within the scatter of the next). At a limit, above all of these: compound 4.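

A bromo group on the shared core, two atoms from the ring nitrogen and meta to the amino group, gives an at least 9.5-fold higher number from compound 1 to compound 4 (0.97 log units; beyond the scatter) in this assay. Going by these compounds alone, the earlier changes gave a 1.3-fold higher number from compound 1 to compound 2 (0.11 log units; within the scatter) and a 1.4-fold lower number from compound 1 to compound 3 (0.14 log units; within the scatter), so this place on the core is the first where a single change moves the number beyond the scatter, and it moves towards a weaker inhibitor. The value of compound 4 is a limit of the assay and not a number: the limit of > 1000000 nM in this assay, at which 1 of the 4 values shown sits.

The compounds shown leave open whether the step belongs to bromo itself or to any group at this place, which a chloro, a methyl or a methoxy there would separate. They also leave open how far compound 4 lies past the limit, and whether the bromo step holds on the core of compound 3, where hydrogen stands in place of the amino group.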